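Removing the ring from the sulfonamide nitrogen of compound 3

The compounds below may be only part of what the source reports. "The series", "measured", "known", "first", "only" and "open" are said of these compounds alone.

Of the compounds shown here, three sharing one core have been measured in a functional assay on SF-295 cells (Homo sapiens) for antiproliferative activity, read by sulforhodamine B assay, with a stated time of 72 h; a higher number here means a weaker inhibitor, a lower number a stronger inhibitor. Compound 1 `O=S(=O)(Nc1ncccn1)c1ccc(Nc2nncc3ccccc23)cc1` gives 7.6 nM, compound 2 `O=S(=O)(Nc1nccs1)c1ccc(Nc2nncc3ccccc23)cc1` gives 6.5 nM, and compound 3 `Cc1cc(NS(=O)(=O)c2ccc(Nc3nncc4ccccc34)cc2)no1` gives 4.4 nM. Compound 3 therefore cannot be told apart from the other two on these numbers.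

The next structure is compound 4 `NS(=O)(=O)c1ccc(Nc2nncc3ccccc23)cc1`, and its difference from compound 3 is hydrogen in place of 5-methyl-1,2-oxazol-3-yl on a sulfonamide nitrogen. In words, this is hydrogen in place of 5-methyl-1,2-oxazol-3-yl on a sulfonamide nitrogen.

The closest evidence comes from swapping one ring for another at that nitrogen: a 1.2-fold lower number from compound 1 to compound 2 (0.07 log units; within the scatter), a 1.7-fold lower number from compound 1 to compound 3 (0.24 log units; within the scatter) and a 1.5-fold lower number from compound 2 to compound 3 (0.17 log units; within the scatter). All three steps are small, but none of them removes the ring altogether, so they guide this change only loosely.

The expected change in this assay is a 1.8-fold higher number from compound 3 to compound 4 (0.26 log units; within the scatter), a slightly higher number that stays within the scatter. For compound 4 the estimated value is 8 nM, with an expected range from 2.5 nM to 30 nM.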

Compound 4, half-maximal inhibitory concentration: 5.3 nM
Beside the measured number, compound 4's estimate is 1.5-fold (0.18 log units) above it; low and high end bracket the measured number.
By their numbers in this assay, from the lowest: compounds 3, 4, 2 and 1 (each within the scatter of the next).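

Replacing the ring on the sulfonamide nitrogen with a plain hydrogen leaves no readable difference in this assay: the steps are (a 1.2-fold higher number from compound 3 to compound 4 (0.08 log units; within the scatter)), (a 1.2-fold lower number from compound 2 to compound 4 (0.09 log units; within the scatter)) and (a 1.4-fold lower number from compound 1 to compound 4 (0.16 log units; within the scatter)). The earlier swaps only exchanged one ring for another, whereas these steps show that, for these four compounds, the number holds with no ring at this position at all. No measurement at hand explains why the number holds here.

The compounds shown leave open whether a non-ring group on this nitrogen, such as a methyl group or a longer carbon chain, would leave the number just as unchanged. They also leave open what a chain ending in a carboxylic acid or an amine would do at this position.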